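The source may hold more compounds than are shown below. What is called first, only, known or untested is meant among the compounds shown, and "the series" means these compounds.

Measured so far in a functional assay on the whole organism for antagonist activity, with Mus musculus as the target; a lower number here means that less compound is needed, a higher number that more compound is needed for the effect:
- Compound 1 `CCC(=O)N(c1ccc(Cl)c(Cl)c1)C1CCCC1O`: 9 mg/kg
- Compound 2 `CN(C)C1CCCC1N(C=O)c1ccccc1`: > 50 mg/kg (a limit of the assay, not a number)

Among the compounds with values here, compound 1 holds the only actual number so far, as compound 2 reached only a limit. Compound 3 `CCCN(CCC)C1CCCC1N(C(=O)CC)c1ccc(Cl)c(Cl)c1` has dipropylamino in place of hydroxy on a saturated ring carbon. Within the data shown here, no measured step shows what this exchange does, so no shift beyond the scatter is expected in this assay, although a somewhat higher dose would not be surprising. The expected change is a 1.7-fold higher number from compound 1 to compound 3 (0.22 log units; within the scatter). Compound 3 is estimated at 15 mg/kg, with an expected range from 4 mg/kg to 60 mg/kg.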

Compound 3, dose for half-maximal effect: 0.1 mg/kg
For compound 3 the middle estimate is 150-fold (2.18 log units) above the measured one; measured number below the stated range.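

In this assay, putting dipropylamino in place of hydroxy on a saturated ring carbon gives a 90-fold lower number from compound 1 to compound 3 (1.95 log units; beyond the scatter) and thus shows that this position accepts a far larger group than hydroxy. The hydroxy is not required for the effect, and its replacement brings a large gain. Nothing measured in this set accounts for the size of this step. As far as these compounds go, it remains open whether the nitrogen or the propyl chains carry the step, and what diethylamino or a piperidine would give on this carbon.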